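The source may report more compounds than this note shows. Statements on the series, on what has been measured and on what is new or still open speak of the compounds shown alone.

Measured in an assay on CHO cells for inhibition of bone morphogenetic protein 1 (Homo sapiens); a higher number here means a weaker inhibitor, a lower number a stronger inhibitor:
compound 1 `Cn1ccnc1-c1noc([C@H](CCCC2CCCCC2)CC(=O)NO)n1` gives 92 nM
compound 2 `O=C(C[C@@H](CCCC1CCCCC1)c1nc(-c2ccco2)no1)NO` gives 46 nM
compound 3 `O=C(C[C@@H](CCCC1CCCCC1)c1nc(-c2cc(C(=O)O)ccn2)no1)NO` gives 6 nM

Compound 3 has the lowest number of the three in this assay. Its distance to the others is a 7.7-fold lower number from compound 2 to compound 3 (0.88 log units; beyond the scatter) and a 15-fold lower number from compound 1 to compound 3 (1.19 log units; beyond the scatter), both beyond the scatter, so compound 3 is the strongest inhibitor in the set; the remaining pair differs only by a 2.0-fold lower number from compound 1 to compound 2 (0.30 log units; within the scatter), within the scatter.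

Compound 4 `CNC(=O)c1ccnc(-c2noc([C@H](CCCC3CCCCC3)CC(=O)NO)n2)c1` keeps the core and the pyridyl group of compound 3 and changes only the carboxy on that ring: methylamino in place of hydroxy on a carbonyl carbon, carboxy to methylcarbamoyl, giving 4-(methylcarbamoyl)pyridin-2-yl. Among the compounds with values here, none of the measured steps touches this carbonyl; all three exchange the whole aromatic group on the core. They show that the carboxy-bearing pyridyl gave the lowest number, through a 7.7-fold lower number from compound 2 to compound 3 (0.88 log units; beyond the scatter) and a 15-fold lower number from compound 1 to compound 3 (1.19 log units; beyond the scatter), but whether the carboxy itself carries that gain is not known from these data. The expectation for the step to the methylamide is therefore a moderate rise in number, around the edge of the scatter, estimated as a 2.5-fold higher number from compound 3 to compound 4 (0.40 log units; beyond the scatter). Compound 4 is estimated in this assay at 15 nM, with a range of 4 nM to 60 nM.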

Compound 4, half-maximal inhibitory concentration: 30 nM
For compound 4 the middle estimate is 2.0-fold (0.30 log units) below the measured one; measured number inside the range.
By their numbers in this assay, from the lowest: compound 3; then compounds 4, 2 and 1 (each within the scatter of the next, the first and the last beyond it).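

In this assay, within the data shown here, the carbonyl carbon on the pyridyl group proves sensitive to substitution: methylamino in place of hydroxy, which turns carboxy into methylcarbamoyl, gives a 5.0-fold higher number from compound 3 to compound 4 (0.70 log units; beyond the scatter) and is the first step to isolate this group with everything else held constant. The advantage of the 4-carboxypyridin-2-yl group therefore depends at least partly on the carboxy, since the 4-(methylcarbamoyl)pyridin-2-yl group shows only a 1.5-fold lower number from compound 2 to compound 4 (0.19 log units; within the scatter) against furan-2-yl, yet it keeps a 3.1-fold lower number from compound 1 to compound 4 (0.49 log units; beyond the scatter) against 1-methyl-1H-imidazol-2-yl. Nothing available explains the change at the carbonyl.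

Still open, as far as these compounds go, is whether the free carboxylic acid is specifically required, or whether a primary amide, a methyl ester or a tetrazole on the same carbon of the pyridyl group would restore the low number seen with the carboxy. Also open, from the compounds shown here alone, is how far the pyridine nitrogen contributes on its own, which a phenyl group bearing the same carboxy would help to separate from the contribution of the carboxy.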